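From chloro to methoxy on a shared core

This account rests on a few compounds, and the source may have more. Where it says the series, first, only, none or still open, it means among the compounds named here.

- compound 1 `COc1ccc(-c2nnc(NC(=O)/C=C/c3ccc(C)cc3)s2)cc1`: 0.58 ug/mL
- compound 2 `COc1ccc(/C=C/C(=O)Nc2nnc(-c3ccccc3)s2)cc1`: 0.76 ug/mL
- compound 3 `COc1ccc(/C=C/C(=O)Nc2nnc(-c3ccc(Cl)cc3)s2)cc1`: 1.38 ug/mL

These values come from a functional assay on A549 cells (Homo sapiens) for antiproliferative activity, read by MTT assay, with a stated time of 48 h; a lower number here means a stronger inhibitor, a higher number a weaker inhibitor. Compound 3, at 1.38 ug/mL, lies within the scatter of compound 2, while compound 1 has a number lower than compound 3 by more than the scatter. Compound 4 `COc1ccc(/C=C/C(=O)Nc2nnc(-c3ccc(OC)cc3)s2)cc1` carries methoxy in place of chloro on an aromatic carbon. Among the compounds with values here, the one measured step touching this group is a 1.8-fold higher number from compound 2 to compound 3 (0.26 log units; within the scatter), with chloro in place of hydrogen. It is small. Compound 1, at 0.58 ug/mL, also carries a 4-methoxyphenyl group. In this assay no change beyond the scatter is therefore expected, with a slight lean towards a lower number. The expected step is a 1.5-fold lower number from compound 3 to compound 4 (0.19 log units; within the scatter). The estimate for compound 4 is 0.9 ug/mL, with an expected range of 0.45 ug/mL to 1.8 ug/mL.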

Compound 4, half-maximal inhibitory concentration: 0.52 ug/mL
Beside the measured number, compound 4's estimate is 1.7-fold (0.24 log units) above it; measured number inside the range.
By their numbers in this assay, from the lowest: compounds 4, 1, 2 and 3 (each within the scatter of the next, the first and the last beyond it).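

Within this assay methoxy in place of chloro gives a 2.7-fold lower number from compound 3 to compound 4 (0.42 log units; beyond the scatter) and so, unlike the earlier step of chloro in place of hydrogen, moves the number beyond the scatter. Methoxy in place of hydrogen gives a 1.5-fold lower number from compound 2 to compound 4 (0.16 log units; within the scatter) and methoxy in place of methyl gives a 1.1-fold lower number from compound 1 to compound 4 (0.05 log units; within the scatter) and both stay within the scatter, so among these single changes only the chloro and methoxy compounds stand clearly apart. No measurement shown here accounts for this gap. Still open, as far as these compounds go, is whether an amine, a carboxylic acid or a longer chain such as ethoxy on this aromatic carbon would fall nearer to chloro or to methoxy.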